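The source may hold more compounds than are shown below. What is called first, only, known or untested is meant among the compounds shown, and "the series" means these compounds.

Working notes on the series. In a functional assay on A549 cells (Homo sapiens) for cytotoxicity, read by MTT assay, with a stated time of 72 h (on this read-out higher numbers stand for weaker inhibition and lower numbers for stronger inhibition), compound 1 `COc1ccc(OC)c(/C=N/NC(=O)Nc2ccc(Oc3ccnc(-c4nncn4CCN(C)C)c3)c(F)c2)c1` gives 1950 nM and stands second highest of the three numbers recorded. Its neighbours are compound 2 `COc1ccc(/C=N/NC(=O)Nc2ccc(Oc3ccnc(-c4nncn4CCN(C)C)c3)c(F)c2)c(OC)c1`, which gives 2820 nM in this assay, and compound 3 `CN(C)CCn1cnnc1-c1cc(Oc2ccc(NC(=O)N/N=C/c3ccc(O)c(Br)c3)cc2F)ccn1`, which gives 1370 nM. Within the data shown here, the step of a 1.4-fold higher number from compound 1 to compound 2 (0.16 log units; within the scatter) and the step of a 1.4-fold lower number from compound 1 to compound 3 (0.15 log units; within the scatter) both sit inside the scatter; only the step of a 2.1-fold lower number from compound 2 to compound 3 (0.31 log units; beyond the scatter) reaches beyond it, and modestly.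

Compound 4 `CN(C)CCn1cnnc1-c1cc(Oc2ccc(NC(=O)N/N=C/c3ccccc3)cc2F)ccn1` differs from compound 1 in one place: phenyl in place of 2,5-dimethoxyphenyl on a carbon with a double bond to nitrogen. Among the measured compounds shown here, the measured steps exchange one substituted phenyl for another substituted phenyl on that carbon; none of them removes every substituent, so no step bears on this change directly. What the three numbers show is that the phenyl substituents on this carbon have moved this assay only by small amounts. The expected step of a 1.3-fold higher number from compound 1 to compound 4 (0.11 log units; within the scatter) is therefore small, with no clear direction beyond the scatter. Compound 4 is estimated at 2500 nM in this assay, within a range of 1100 nM to 6000 nM.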

Compound 4, half-maximal inhibitory concentration: 1860 nM
Compound 4: middle estimate off by 1.3-fold (0.13 log units), on the high side, within the range that was stated.
By their numbers in this assay, from the lowest: compounds 3, 4, 1 and 2 (each within the scatter of the next, the first and the last beyond it).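

With the phenyl on this carbon stripped of every substituent, this assay gives the step of a 1.0-fold lower number from compound 1 to compound 4 (0.02 log units; within the scatter) and also the steps of a 1.4-fold higher number from compound 3 to compound 4 (0.13 log units; within the scatter) and a 1.5-fold lower number from compound 2 to compound 4 (0.18 log units; within the scatter), all within the scatter. The phenyl of compound 4 therefore cannot be told apart in this read-out from any of the three substituted phenyl groups, so neither the two methoxy groups nor the bromo and hydroxy pair are shown to be needed at this position. No measured evidence bears on why this position responds so little.

From the compounds shown here alone, it remains open whether a phenyl carrying an amine or a carboxylic acid would move the number beyond the scatter. Also open, going by these compounds, is whether a longer chain in place of the phenyl on this carbon would do so.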